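This account rests on a few compounds, and the source may have more. Where it says the series, first, only, none or still open, it means among the compounds named here.

The shared core carries an amide on one ring, and the group on its carbonyl carbon is what varies. Compound 1 `COc1cc(/C=C/C(=O)c2cccc(NC(=O)c3ccc(Cl)c(Cl)c3)c2)ccc1O` bears a 3,4-dichlorophenyl there; in a functional assay on Vero cells (Chlorocebus sabaeus) for inhibition (a lower number here means a stronger inhibitor, a higher number a weaker inhibitor), compound 1 reaches > 50 ug/mL, which is a limit of the assay rather than a number. Among the compounds with values here, compound 2 `COc1cc(/C=C/C(=O)c2cccc(NC(=O)C(C)C)c2)ccc1O` carries isopropyl instead, and in this assay compound 2 gives 3.47 ug/mL, the only real number among the two values. Within the data shown here, the one measured step, an at least 14-fold lower number from compound 1 to compound 2 (1.15 log units; beyond the scatter), is known only as a minimum because compound 1 sits at the limit of > 50 ug/mL in this assay, at which 1 of the 2 values shown sits. Compound 3 `COc1cc(/C=C/C(=O)c2cccc(NC(C)=O)c2)ccc1O` differs from compound 2 by methyl in place of isopropyl on a carbonyl carbon. That measured step traded 3,4-dichlorophenyl for isopropyl, whereas the present change moves from isopropyl to methyl, so the expected step in this assay is a small one, a 1.3-fold higher number from compound 2 to compound 3 (0.11 log units; within the scatter), not beyond the scatter. Compound 3 is therefore estimated at 4.5 ug/mL, within 1.5 ug/mL to 14 ug/mL.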

Compound 3, half-maximal inhibitory concentration: 14.5 ug/mL
Estimate against measurement, compound 3: 3.2-fold (0.51 log units) below; the whole stated range lies below it.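

Shortening the group on the carbonyl carbon from isopropyl to methyl gives a 4.2-fold higher number from compound 2 to compound 3 (0.62 log units; beyond the scatter) in this assay, so even two small groups at this position are told apart. Methyl still does better than 3,4-dichlorophenyl, with an at least 3.4-fold lower number from compound 1 to compound 3 (0.53 log units; beyond the scatter) as the step, which puts compound 2, with the group of middle size, ahead of both compound 1 and compound 3 and shows that the number does not move in one direction with group size. That last step is only a minimum because compound 1 sits at a limit of the assay: the limit of > 50 ug/mL in this assay, at which 1 of the 3 values shown sits.

The compounds shown leave open whether the best group lies close to isopropyl, which a cyclopropyl, a tert-butyl or a longer chain on this carbonyl carbon could settle. Also open, as far as these compounds go, is whether the weak result with 3,4-dichlorophenyl belongs to the ring or to its two chlorines, which a plain phenyl would separate.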